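This account rests on a few compounds, and the source may have more. Where it says the series, first, only, none or still open, it means among the compounds named here.

Measured compounds:

Compound 1, `Nc1nc(N/N=C/c2ccc(-c3ccc(Br)cc3)o2)nc2c1ncn2[C@@H]1O[C@H](CO)[C@@H](O)[C@H]1O`: 4.5 nM
Compound 2, `Nc1nc(N/N=C/c2ccc(N(c3ccccc3)c3ccccc3)cc2)nc2c1ncn2[C@@H]1O[C@H](CO)[C@@H](O)[C@H]1O`: a limit, > 10000 nM
Compound 3, `Nc1nc(N/N=C/c2ccc(-c3ccccc3)cc2)nc2c1ncn2[C@@H]1O[C@H](CO)[C@@H](O)[C@H]1O`: 7860 nM

All three share one core and differ only in the group hanging off the hydrazone arm. In an assay on CHO-K1 cells for displacement of a labelled ligand from adenosine receptor A1 (Homo sapiens), read by scintillation counting, with a stated time of 60 min (on this read-out lower numbers stand for stronger inhibition and higher numbers for weaker inhibition), compound 3 gives 7860 nM, which is the higher of the two numbers actually measured. Compound 1 gives 4.5 nM in this assay, a gap that lies far beyond the usual scatter. For compound 2 this assay reports only a limit, > 10000 nM; such a limit is described as the limit of > 10000 nM in this assay, at which 1 of the 3 values shown sits, and is not a number.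

The next compound, compound 4, is `Nc1nc(N/N=C/c2ccc(C(F)(F)F)cc2)nc2c1ncn2[C@@H]1O[C@H](CO)[C@@H](O)[C@H]1O`. It differs from compound 3 in one place: trifluoromethyl in place of phenyl on an aromatic carbon. Within the data shown here, no measured pair here shows what this kind of exchange does, so the direction of the step cannot be read from the data. With compound 3 already at the weak end of what was measured, a step of modest size in either direction is expected, close to the scatter, and the expected step from compound 3 is a 1.3-fold lower number from compound 3 to compound 4 (0.12 log units; within the scatter). Compound 4 is therefore estimated to give about 6000 nM in this assay, within a range from 1000 nM to 30000 nM.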

Compound 4, inhibition constant: 37 nM
Estimate against measurement, compound 4: 160-fold (2.21 log units) above, and the stated range ends above it.
By their numbers in this assay, from the lowest: compound 1; then compound 4; then compound 3. At a limit, above all of these: compound 2.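

Among these compounds, this is the first pair that differs in one place only, so it gives the first direct reading of what this aromatic carbon, para to a large group, can do. In this assay, trifluoromethyl in place of phenyl gives a 210-fold lower number from compound 3 to compound 4 (2.33 log units; beyond the scatter), and since a lower number stands for stronger inhibition, the smaller group without a ring is clearly the better of these two here. The position is therefore far from indifferent, and a ring of carbon is not needed on it for strong inhibition, although nothing measured here explains why the number falls so far.

A single pair cannot separate the loss of the phenyl ring from the arrival of the fluorine atoms, and a methyl group, a chlorine atom or a plain hydrogen on this carbon would help to tell those two apart. Also open, going by these compounds, are whether an amine or a carboxylic acid at this place would be tolerated, and whether the same exchange has a similar effect when the rest of the side arm is different.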